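The compounds below may be only part of what the source reports. "The series", "measured", "known", "first", "only" and "open" are said of these compounds alone.

Measured compounds in an ADME assay on HCT-116 cells (Homo sapiens) for cytotoxicity, read by CellTiter-Glo, with a stated time of 72 h; a higher number here means a weaker inhibitor, a lower number a stronger inhibitor:

- compound 1 `CC1CCN(C2CCN(S(=O)(=O)c3ccc(C(C)(C)C)cc3)CC2)CC1`: > 5000 nM
- compound 2 `CC(=O)Nc1ccc(S(=O)(=O)N2CCC(N3CCC(C)CC3)CC2)c2ccccc12`: > 10000 nM
- compound 3 `CC1CCN(C2CCN(S(=O)(=O)c3cccc(N)c3)CC2)CC1`: > 5000 nM

All three results in this assay are limits of the assay rather than numbers. For compound 1 the result > 5000 nM is a limit, so compound 1 stands at the threshold of the assay and no ranking of it against the others can be made. The value of compound 2 is likewise a limit, at the limit of > 10000 nM in this assay, at which 1 of the 3 values shown sits. Compound 3 sits, as compound 1 does, at the limit of > 5000 nM in this assay, at which 2 of the 3 values shown sit. Going by the values given here, no step between two measured compounds can be computed from limits alone.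

Compound 4 `CC1CCN(C2CCN(S(=O)(=O)c3ccc(-c4ccc(Cl)cc4)cc3)CC2)CC1` differs from compound 1 by 4-chlorophenyl in place of tert-butyl on an aromatic carbon. Among the compounds with values here, no measured step in this assay accompanies this change, and the three measured compounds give only limits, so the size of the step from compound 1 to compound 4 in this assay is open. The expectation is that the step that the limit leaves unreadable from compound 1 to compound 4 stays close to the scatter, with a modest move toward stronger inhibition held possible. Compound 4 is therefore estimated at 8000 nM in this assay, within a range from 2000 nM to 30000 nM, and a further limit read-out is the more likely outcome.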

Compound 4, half-maximal inhibitory concentration: > 5000 nM
Compound 4: no number, only a limit (the forecaster's own chance of this, stated with the estimate: 60%); the middle value is on the limit's open side.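

In this assay compound 4 gives > 5000 nM, which is a limit and not a number. Going by these compounds alone, no step between compound 1 and compound 4 can be read. The compounds shown leave open where any of them would fall as a number, and whether 4-chlorophenyl in place of tert-butyl on an aromatic carbon changes the read-out at all.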